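The source may hold more compounds than are shown below. What is called first, only, known or untested is meant among the compounds shown, and "the series" means these compounds.

Of the compounds shown here, three built on one shared core have been tested in a functional assay on SW480 cells (Homo sapiens) for cytotoxicity, read by MTT assay, with a stated time of 48 h; on this read-out higher numbers stand for weaker inhibition and lower numbers for stronger inhibition. Compound 1 `O=c1ccoc2cc(OCc3cn(Cc4ccc(Cl)cc4)nn3)ccc12` gives only a limit there, > 100000 nM. Compound 2 `O=c1ccoc2cc(OCc3cn(Cc4ccc(Cl)cc4Cl)nn3)ccc12` also gives only a limit, > 100000 nM. Going by the values given here, compound 3 `O=c1ccoc2cc(OCc3cn(Cc4ccccc4Cl)nn3)ccc12` is the single compound with a number in this assay, 23500 nM, and so stands alone as the one readable value. The untested compound 4 `COc1ccc(Cn2cc(COc3ccc4c(=O)ccoc4c3)nn2)cc1` differs from compound 3 in one place: 4-methoxyphenyl in place of 2-chlorophenyl on a saturated chain carbon bound to an aromatic nitrogen. The step that bears on this change is an at least 4.2-fold lower number from compound 1 to compound 3 (0.62 log units; beyond the scatter), a move from 4-chlorophenyl to 2-chlorophenyl; compound 4 returns to a 4-substituted pattern, closer to compound 1, though with methoxy rather than chloro. Compound 4 is therefore expected to give a higher number, estimated at 80000 nM, within a range of 25000 nM to 300000 nM. That estimate corresponds to an expected step of a 3.4-fold higher number from compound 3 to compound 4 (0.53 log units; beyond the scatter), possibly ending again at a limit.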

Compound 4, half-maximal inhibitory concentration: 20400 nM
For compound 4 the middle estimate is 3.9-fold (0.59 log units) above the measured one; the whole stated range lies above it.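

In this assay, 4-methoxyphenyl in place of 2-chlorophenyl on a saturated chain carbon bound to an aromatic nitrogen brings no change beyond the scatter, with a 1.2-fold lower number from compound 3 to compound 4 (0.06 log units; within the scatter). A 4-substituted phenyl can thus give a readable number here, as methoxy in place of chloro gives an at least 4.9-fold lower number from compound 1 to compound 4 (0.69 log units; beyond the scatter), and 4-methoxyphenyl in place of 2,4-dichlorophenyl gives an at least 4.9-fold lower number from compound 2 to compound 4 (0.69 log units; beyond the scatter). Both of these steps are only bounds, as each starts from a limit and not a number: the limit of > 100000 nM in this assay, at which 2 of the 4 values shown sit.

Going by these compounds, what an unsubstituted phenyl, an amine or a carboxylic acid would give at this place stays open.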